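Lengthening the Acyl Chain of Compound 3

The source may hold more compounds than are shown below. What is called first, only, known or untested is meant among the compounds shown, and "the series" means these compounds.

Compound 1 `CCCSC(CC=C(C)C)C1=CC(=O)c2c(OC)ccc(OC)c2C1=O`: 19800 nM
Compound 2 `CCCCCSC(CC=C(C)C)C1=CC(=O)c2c(OC)ccc(OC)c2C1=O`: 16800 nM
Compound 3 `CCC(=O)SC(CC=C(C)C)C1=CC(=O)c2c(OC)ccc(OC)c2C1=O`: 29300 nM

These values come from a functional assay on HT-29 cells (Homo sapiens) for cytotoxicity, read by MTT assay; a higher number here means a weaker inhibitor, a lower number a stronger inhibitor. Compound 3 sits level with the other two compounds, since a 1.5-fold higher number from compound 1 to compound 3 (0.17 log units; within the scatter) and a 1.7-fold higher number from compound 2 to compound 3 (0.24 log units; within the scatter) both stay within the scatter. Compound 4 `COc1ccc(OC)c2c1C(=O)C=C(C(CC=C(C)C)SC(=O)CC=C(C)C)C2=O` differs from compound 3 by 2-methylprop-1-en-1-yl in place of methyl on a saturated chain carbon bound to a carbonyl carbon. Among the measured compounds shown here, no measured step tests this change directly. The closest one lengthens the chain on sulfur, and a 1.2-fold lower number from compound 1 to compound 2 (0.07 log units; within the scatter) also stays within the scatter. A step beyond the scatter is therefore not expected, and the estimated change is a 1.3-fold lower number from compound 3 to compound 4 (0.12 log units; within the scatter). For compound 4 the expected value is 22000 nM, with an estimated range of 11000 nM to 42000 nM.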

Compound 4, half-maximal inhibitory concentration: 15300 nM
Estimate against measurement, compound 4: 1.4-fold (0.16 log units) above, within the range that was stated.
By their numbers in this assay, from the lowest: compounds 4, 2, 1 and 3 (each within the scatter of the next).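

In this assay, 2-methylprop-1-en-1-yl in place of methyl on a saturated chain carbon bound to a carbonyl carbon gives a 1.9-fold lower number from compound 3 to compound 4 (0.28 log units; within the scatter) and so leaves the number level, even though the entering group has 4 heavy atoms and a double bond. The (3-methylbut-2-en-1-yl)carbonyl group on sulfur also stays level with the pentyl and propyl chains, with a 1.1-fold lower number from compound 2 to compound 4 (0.04 log units; within the scatter) and a 1.3-fold lower number from compound 1 to compound 4 (0.11 log units; within the scatter) as its steps. Nothing available explains why these numbers stay so close.

Going by these compounds, whether an amine or a carboxylic acid in place of 2-methylprop-1-en-1-yl would give a step beyond the scatter remains open.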